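The source may report more compounds than this note shows. Statements on the series, on what has been measured and on what is new or still open speak of the compounds shown alone.

Liver microsomes are a standard laboratory test of how quickly a compound is broken down, and three related compounds have been measured this way so far. In an ADME assay (liver) for metabolic stability, with Liver microsome (Homo sapiens) as the target, read by LC-MS, using microsomes and NADPH, with a stated time of 5 min, at 37 degrees C (on this read-out higher numbers stand for fast clearance and lower numbers for slow clearance), compound 1 `CCn1c([C@@H](C)NS(=O)(=O)c2ccc(Cl)cc2)nc2ccccc21` gives > 100 mL.min-1.g-1, which is a limit of the assay and not a number. Compound 2 `CCn1c(C(C)NS(=O)(=O)c2ccc(Cl)cc2)nc2cnccc21` gives 35 mL.min-1.g-1, and compound 3 `CCn1c([C@@H](C)NS(=O)(=O)c2ccc(F)cc2)nc2ccc(C(F)(F)F)cc21` gives 26 mL.min-1.g-1. These last two values lie within the usual scatter of each other, so compound 3 stands level with compound 2 at the slow-clearance end of what has been seen.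

The next molecule is compound 4 `CCn1c([C@@H](C)NS(=O)(=O)c2ccc(CC(C)C)cc2)nc2ccc(C(F)(F)F)cc21`. It keeps everything in compound 3 except for one substituent, where isobutyl takes the place of fluoro on an aromatic carbon, para to a large group: isobutyl in place of fluoro on an aromatic carbon.

For the measured compounds named here, no two measured compounds differ in one place only, which leaves this swap without a direct precedent, and any forecast is a judgement rather than a reading from the data. With compound 3 at 26 mL.min-1.g-1, there is still room for the number to rise. The expected change is an increase towards faster clearance, beyond the scatter, estimated as a 2.7-fold higher number from compound 3 to compound 4 (0.43 log units; beyond the scatter). For compound 4 the estimated value in this assay is 70 mL.min-1.g-1, with an expected range of 35 mL.min-1.g-1 to 140 mL.min-1.g-1.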

Compound 4, intrinsic clearance in microsomes: > 100 mL.min-1.g-1
Compound 4 ended at the assay's limit (the forecaster's own chance of this, stated with the estimate: 30%); middle value at least 1.4-fold (0.15 log units) away from the limit.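

For the compounds shown here, replacing fluoro with isobutyl on this aromatic carbon gives an at least 3.8-fold higher number from compound 3 to compound 4 (0.58 log units; beyond the scatter) in this assay, the first step that changes one place only, and it shows that the group at this position can make a clear difference to clearance. The value for compound 4, > 100 mL.min-1.g-1, is a limit of the assay and not a number. The step is therefore a minimum, its full size remains unknown, and compounds at this ceiling cannot be told apart: the limit of > 100 mL.min-1.g-1 in this assay, at which 2 of the 4 values shown sit.

A single swap cannot show whether any carbon group at this position would give a similar rise or whether the effect is particular to isobutyl, and a methyl, a methoxy or a carboxylic acid on the same aromatic carbon would help to separate these possibilities. From the compounds shown here alone, it also remains open whether the same swap would give a step of similar size on a different core, such as the core of compound 2.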